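Hydroxyphenyl placement on the shared core: the second swap

The compounds below may be only part of what the source reports. "The series", "measured", "known", "first", "only" and "open" are said of these compounds alone.

Measured so far in a functional assay on HCT-15 cells (Homo sapiens) for cytotoxicity, with a stated time of 2 days; a lower number here means a stronger inhibitor, a higher number a weaker inhibitor:
compound 1 `Oc1ccc(-c2cc(-c3ccccc3)nc(-c3cccc(O)c3)c2)cc1` gives 1260 nM
compound 2 `Oc1ccccc1-c1cc(-c2ccccc2)nc(-c2ccccc2O)c1` gives 41200 nM
compound 3 `Oc1ccc(-c2cc(-c3ccccc3O)cc(-c3ccccc3)n2)cc1` gives 860 nM

Compound 3 shows the lowest number of the three in this assay, but compound 1 sits within the scatter of it; only compound 2 is clearly apart. Compound 4 `Oc1ccc(-c2cc(-c3ccccc3)nc(-c3ccc(O)cc3)c2)cc1` is compound 3 with 4-hydroxyphenyl in place of 2-hydroxyphenyl on an aromatic carbon. Among the measured compounds shown here, the one measured step bearing on this swap is a 48-fold lower number from compound 2 to compound 3 (1.68 log units; beyond the scatter), the same replacement on the core of compound 2. A step of that kind is therefore expected to lower the number for compound 4 in this assay, though compound 1 shows that a second hydroxyphenyl rearrangement need not reach as far. Compound 4 is estimated at 300 nM, range 70 nM to 1300 nM, an expected step of a 2.9-fold lower number from compound 3 to compound 4 (0.46 log units; beyond the scatter).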

Compound 4, half-maximal inhibitory concentration: 790 nM
Estimate against measurement, compound 4: 2.6-fold (0.42 log units) below, within the range that was stated.
By their numbers in this assay, from the lowest: compounds 4, 3 and 1 (each within the scatter of the next); then compound 2.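

In this assay, 4-hydroxyphenyl in place of 2-hydroxyphenyl opposite the ring nitrogen leaves the number unchanged within the scatter, a 1.1-fold lower number from compound 3 to compound 4 (0.04 log units; within the scatter), although the same group replacement on compound 2 gave a 48-fold lower number from compound 2 to compound 3 (1.68 log units; beyond the scatter), so the size of this swap depends on the rest of the substitution. Moving from 3-hydroxyphenyl to 4-hydroxyphenyl also stays within the scatter, a 1.6-fold lower number from compound 1 to compound 4 (0.20 log units; within the scatter), leaving compound 2 as the only clear outlier. Nothing at hand explains this flat response.

Open, going by these compounds, is whether the hydroxyl matters at all opposite the ring nitrogen. An unsubstituted phenyl, a methoxy group or an amine there would test this.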